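This account rests on a few compounds, and the source may have more. Where it says the series, first, only, none or still open, it means among the compounds named here.

Working notes on the aminothiophene series

The shared core of compound 3, `Nc1scc(CN2CCN(c3cccc(F)c3F)CC2)c1C(=O)c1ccc(Cl)cc1`, carries a 2,3-difluorophenyl group on the ring nitrogen. Going by the values given here, in a functional assay on CHO cells with adenosine receptor A1 (Homo sapiens) as the target, read by cAMP accumulation and immunoassay, with a stated time of 6 min, tested at 0.1 uM (a higher number here means a weaker effect of the compound at the concentration tested, a lower number a stronger effect), compound 3 gives -5.2%, the highest of the three numbers measured so far. Compound 1, `Nc1scc(CN2CCN(c3ccccc3C(F)(F)F)CC2)c1C(=O)c1ccc(Cl)cc1`, gives -7.5% in this assay, and the two lie within the scatter of each other: a number 2.3 percentage points higher from compound 1 to compound 3 (within the scatter). Compound 2, `Nc1scc(CN2CCN(c3cccc(F)c3)CC2)c1C(=O)c1ccc(Cl)cc1`, gives -37%, and the step of a number 31.8 percentage points higher from compound 2 to compound 3 (beyond the scatter) is the only one in the set that clears the scatter by a wide margin; the step of a number 29.5 percentage points lower from compound 1 to compound 2 (beyond the scatter) points the same way.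

Compound 4, `Nc1scc(CN2CCN(c3cc(F)ccc3F)CC2)c1C(=O)c1ccc(Cl)cc1`, is the next member. The change from compound 3 is 2,5-difluorophenyl in place of 2,3-difluorophenyl on an amine nitrogen in a ring. The step from compound 1 to compound 3 shows that exchanging one substituted phenyl for another on this nitrogen can leave the number unmoved, while the step from compound 2 to compound 3 shows that a single fluorine can shift it a great deal. Among the compounds with values here, no measured pair separates the two difluorophenyl patterns directly, so the expectation is a step of a number 4.8 percentage points lower from compound 3 to compound 4 (within the scatter), probably small and downward but uncertain. Compound 4 is estimated at -10%, with a range from -30% to 8%.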

Compound 4, a percentage reported as activity, at one concentration (the size of the read-out at that concentration, not a potency): -13%
For compound 4 the middle estimate is 3 percentage points above the measured one, within the range that was stated.
By their numbers in this assay, from the lowest: compound 2; then compounds 4, 1 and 3 (each within the scatter of the next).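

In this assay the exchange of 2,3-difluorophenyl for 2,5-difluorophenyl on the amine nitrogen in a ring gives a step within the scatter (a number 7.8 percentage points lower from compound 3 to compound 4 (within the scatter)), so these two difluorophenyl patterns are not told apart. Fluoro in place of hydrogen on the aromatic carbon of compound 2 now gives a second step beyond the scatter (a number 24 percentage points higher from compound 2 to compound 4 (beyond the scatter)), so both difluorophenyl compounds part from compound 2. The 2-(trifluoromethyl)phenyl group of compound 1 and the 2,5-difluorophenyl group also stay within the scatter of each other (a number 5.5 percentage points lower from compound 1 to compound 4 (within the scatter)), and nothing at hand gives a reason for any of these steps.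

On these data alone, how a methoxy group or a nitrile on this phenyl ring would read remains open. The same holds for a pyridine ring in its place, and these numbers speak only of a stronger or weaker effect at the one concentration tested.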